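The compounds below may be only part of what the source reports. "The series", "measured", "known", "first", "only" and "open" are said of these compounds alone.

Measured compounds in a functional assay on HCT-116 cells (Homo sapiens) for inhibition, read by MTT assay, with a stated time of 24 h, tested at 10 uM; on this read-out higher numbers stand for more inhibition of growth at the one concentration tested and lower numbers for less inhibition of growth:
compound 1 `N#Cc1ccc(-c2cnc3[nH]cc(-c4nnc(-c5ccc(F)cc5)o4)c(=O)c3c2)cc1`, compound 1 gives 18.9%
compound 2 `O=c1c(-c2nnc(-c3ccc(F)cc3)o2)c[nH]c2ncc(-c3cccnc3)cc12`, compound 2 gives 19.7%
compound 3 `N#Cc1ccc(-c2cnc3[nH]cc(-c4nnc(-c5ccc(Cl)cc5)o4)c(=O)c3c2)cc1`, compound 3 gives 18.3%

Compound 4 `O=c1c(-c2nnc(-c3ccc(Cl)cc3)o2)c[nH]c2ncc(-c3cccnc3)cc12` has not yet been measured. It differs from compound 3 in one place: pyridin-3-yl in place of 4-cyanophenyl on an aromatic carbon. The same change separates compound 1 from compound 2: pyridin-3-yl in place of 4-cyanophenyl on an aromatic carbon. Both place descriptions are the same word for word, so the change can be called the same, and in the measured pair it made a step of a number 0.8 percentage points higher from compound 1 to compound 2 (within the scatter). The two cores differ as well: chloro in place of fluoro on an aromatic carbon, a change that gave a number 0.6 percentage points lower from compound 1 to compound 3 (within the scatter). Because the measured step of a number 0.8 percentage points higher from compound 1 to compound 2 (within the scatter) was small, the step in this assay is expected to be a number 0.8 percentage points higher from compound 3 to compound 4 (within the scatter). Compound 4 is therefore estimated at 19.1%, most likely falling between 9% and 29%.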

Compound 4, percent growth inhibition at one concentration: 11.8%
The estimate for compound 4 lay 7.3 percentage points above the measured number; low and high end bracket the measured number.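

In this assay, pyridin-3-yl in place of 4-cyanophenyl gave a number 6.5 percentage points lower from compound 3 to compound 4 (within the scatter), and chloro in place of fluoro gave a number 7.9 percentage points lower from compound 2 to compound 4 (within the scatter). The pyridin-3-yl change therefore carries from the core of compound 1 to the core of compound 3 with no gap beyond the scatter: the same change on two cores in this assay, a number 0.8 percentage points higher (within the scatter) from compound 1 to compound 2 and a number 6.5 percentage points lower (within the scatter) from compound 3 to compound 4, 7.3 percentage points apart, within the scatter of two such steps The chloro change also carries between its two cores with no gap beyond the scatter, though neither comparison proves that the steps are equal or that they would hold on other cores: the same change on two cores in this assay, a number 0.6 percentage points lower (within the scatter) from compound 1 to compound 3 and a number 7.9 percentage points lower (within the scatter) from compound 2 to compound 4, 7.3 percentage points apart, within the scatter of two such steps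

Still open, going by these compounds, is whether an amine or a carboxylic acid in the place of pyridin-3-yl would move the number beyond the scatter. The same question stands for a methoxy group in place of the halogen.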